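This account rests on a few compounds, and the source may have more. Where it says the series, first, only, none or still open, it means among the compounds named here.

Compound 1 `CCCN(CC1CC1)c1cc(C)nc2c(-c3ncc(Cl)cc3Cl)c(C)nn12`: 3.9 nM in an assay on isolated protein for binding affinity to corticotropin-releasing factor receptor 1 (Homo sapiens); a higher number here means a weaker inhibitor, a lower number a stronger inhibitor
Compound 2 `CCCN(CCC)c1cc(C)nc2c(-c3ncc([N+](=O)[O-])cc3C)c(C)nn12`: 9.1 nM in this assay

Of these two numbers, compound 2 has the higher one; its nearest neighbour, compound 1, sits lower by a margin beyond the scatter. Compound 3 `CCCN(CCC)c1cc(C)nc2c(-c3ncc(N4CCCCC4)cc3C)c(C)nn12` differs from compound 2 by piperidin-1-yl in place of nitro on an aromatic carbon, the shared core otherwise unchanged. Among the measured compounds shown here, no measured pair isolates this exchange, so no step of its kind is known. The step is expected to be a 2.7-fold higher number from compound 2 to compound 3 (0.44 log units; beyond the scatter), a moderate weakening beyond the scatter. For compound 3 in this assay the estimate is 25 nM, within a range of 5 nM to 120 nM.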

Compound 3, inhibition constant: 17 nM
Beside the measured number, compound 3's estimate is 1.5-fold (0.17 log units) above it; low and high end bracket the measured number.
By their numbers in this assay, from the lowest: compound 1; then compounds 2 and 3 (each within the scatter of the next).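

In this assay, placing piperidin-1-yl where nitro stood gives a 1.9-fold higher number from compound 2 to compound 3 (0.27 log units; within the scatter), so compound 2 and compound 3 cannot be told apart. This aromatic carbon, two atoms from the ring nitrogen, therefore carries a six-membered non-aromatic ring of 6 heavy atoms as well as a nitro group of 3 heavy atoms with no change beyond the scatter, although the two groups share little in shape or atoms. No supporting measurement accounts for this result. Going by these compounds, it remains open whether a morpholine ring, a dimethylamino group or a carboxylic acid on this same carbon would read alike.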